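The source may hold more compounds than are shown below. What is called first, only, known or untested is meant among the compounds shown, and "the series" means these compounds.

Compound 3 `CCCCCCC#Cc1cc(C#N)ccc1COC(c1ccc(C#N)cc1)c1cncn1C` stands in a functional assay on NIH3T3 cells (Mus musculus) (a higher number here means that more compound is needed for the effect, a lower number that less compound is needed), at a limit rather than at a number: it gives > 0.1 nM. Compound 1 `Cn1cncc1C(OCc1ccc(C#N)cc1C#Cc1cccc(O)c1)c1ccc(C#N)cc1` likewise stops at a limit in this assay, giving > 0.1 nM. Only compound 2 `Cn1cncc1C(OCc1ccc(C#N)cc1C#Cc1ccccc1)c1ccc(C#N)cc1` yields a number in this assay, namely 0.1 nM. Two of the three values therefore sit at the limit of > 0.1 nM in this assay, at which 2 of the 3 values shown sit. The step of a number no higher from compound 1 to compound 2 (the limit leaves the size open) and the step that the two limits leave unreadable from compound 1 to compound 3 cannot be sized, and the step of a number no lower from compound 2 to compound 3 (the limit leaves the size open), hexyl in place of phenyl on a triple-bonded carbon, is read only as a number no lower. Compound 4 `Cn1cncc1C(OCc1ccc(C#N)cc1C#Cc1ccc(-c2ccccc2)cc1)c1ccc(C#N)cc1` differs from compound 3 by 4-phenylphenyl in place of hexyl on a triple-bonded carbon. This change bears most closely on the step from compound 2 to compound 3, which replaced an aromatic ring with a chain; here an aromatic group returns, larger than before. Since that step could be sized only as no lower, no direction beyond the scatter can be read from it. Compound 4 is therefore expected to stay close to the limit, with an estimated value of 0.2 nM, between 0.1 nM and 1 nM, and an expected step that the limit leaves unreadable from compound 3 to compound 4.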

Compound 4, half-maximal effective concentration: > 0.1 nM
Compound 4 gave a limit, no number; the forecaster's own chance of this, stated with the estimate: 60%; the middle value lies beyond the limit too.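

In this assay, going by these compounds alone, phenyl in place of hydrogen on an aromatic carbon gives a number no lower from compound 2 to compound 4 (the limit leaves the size open), which is the first sign that the terminal phenyl of compound 2 may not take a further aromatic ring without a loss. The steps joining compound 4 to compound 1 and compound 3 cannot be read, since both ends of each are limits. On the triple-bonded carbon, neither hexyl nor 4-phenylphenyl returns a number, and compound 2 remains the only compound with one: the limit of > 0.1 nM in this assay, at which 3 of the 4 values shown sit.

On these data alone, how far compound 1, compound 3 and compound 4 lie past that limit stays open, so these three cannot be ranked. Also open, as far as these compounds go, is whether a smaller group, such as a methyl or an amine, in place of that same hydrogen of compound 2 would still give a number.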